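This account rests on a few compounds, and the source may have more. Where it says the series, first, only, none or still open, it means among the compounds named here.

Among the three compounds measured so far, compound 3 `CCOc1cc(=O)n(CCCO)c2c1CC(CC=C(C)C)C(C)(C)C2` stands highest: in a functional assay on PANC-1 cells (Homo sapiens) for inhibition, read by MTT assay, with a stated time of 24 h, tested at 10 uM (a lower number here means less inhibition, a higher number more inhibition at the concentration tested (going by the name of the read-out)), compound 3 gives 66.5%. Compound 2 `CC(C)=CCC/C(C)=C/CC1Cc2c(O)cc(=O)n(CCCO)c2CC1(C)C` gives 28.7% in this assay, and compound 1 `CC(C)=CCC1Cc2c(O)cc(=O)n(CCCO)c2CC1(C)C` gives 25.6%. The step of a number 3.1 percentage points higher from compound 1 to compound 2 (within the scatter) lies within the scatter, whereas the step of a number 40.9 percentage points higher from compound 1 to compound 3 (beyond the scatter) is large and beyond it, so compound 3 is separated from both others by more than the scatter.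

Compound 4 `CC(C)=CCC1Cc2c(OCc3ccccc3)cc(=O)n(CCCO)c2CC1(C)C` differs from compound 3 in one place: phenyl in place of methyl on a saturated chain carbon bound to an oxygen on an aromatic ring. Going by the values given here, no measured step covers this exact change; the only step that touches the oxygen on the aromatic ring is the one from compound 1 to compound 3, ethyl in place of hydrogen, which raised the number strongly. That step shows that a substituent on this oxygen is compatible with a high number, but it says nothing about replacing methyl by phenyl on the saturated chain carbon bound to that oxygen. The expectation is therefore a step of a number 8.5 percentage points lower from compound 3 to compound 4 (within the scatter), without confidence in its direction. For compound 4 the estimate in this assay is 58%, with a range from 35% to 80%.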

Compound 4, a percentage reported as inhibition, at one concentration (the size of the read-out at that concentration, not a potency): -0.3%
For compound 4 the middle estimate is 58.3 percentage points above the measured one; measured number below the stated range.
By their numbers in this assay, from the lowest: compound 4; then compounds 1 and 2 (each within the scatter of the next); then compound 3.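

In this assay, the oxygen on the aromatic ring does not treat all its substituents alike: going from ethoxy to benzyloxy gives a number 66.8 percentage points lower from compound 3 to compound 4 (beyond the scatter), so a substituent here is not enough in itself to give a high number. Benzyl in place of hydrogen on this oxygen gives a number 25.9 percentage points lower from compound 1 to compound 4 (beyond the scatter), while ethyl in place of hydrogen gave a number 40.9 percentage points higher from compound 1 to compound 3 (beyond the scatter), so at this one position the direction of the step depends on the group placed there. Nothing at hand bears on why these two groups part so sharply.

As far as these compounds go, it remains open whether a longer chain such as butyl, or a saturated cyclohexylmethyl group, on this oxygen would stay near compound 3 or fall towards compound 4. From the compounds shown here alone, it is also open whether a phenyl ring carrying an amine would behave as benzyl does.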